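Trifluoromethyl for methyl on the benzyl ether of compound 2

This account rests on a few compounds, and the source may have more. Where it says the series, first, only, none or still open, it means among the compounds named here.

Two members of this oxime-ether series have been measured. In a functional assay on A549 cells (Homo sapiens) for cytotoxicity, read by MTT assay, with a stated time of 2 days (a lower number here means a stronger inhibitor, a higher number a weaker inhibitor), compound 1 `N#Cc1ccc2c(c1)/C(=N\OCc1ccccc1)C(c1c[nH]c3ccc(C#N)cc13)=N2` gives 14200 nM, and compound 2 `Cc1ccc(CO/N=C2/C(c3c[nH]c4ccccc34)=Nc3ccccc32)cc1` gives 22400 nM in this assay. Compound 2 stands next to compound 1 alone, and the gap between the two numbers lies within the scatter, so they cannot be told apart. Compound 3 `FC(F)(F)c1ccc(CO/N=C2/C(c3c[nH]c4ccccc34)=Nc3ccccc32)cc1` differs from compound 2 by trifluoromethyl in place of methyl on an aromatic carbon, para to a large group. For the measured compounds named here, no measured pair shows what this exchange does here, so nothing firm can be read across. The step is expected to stay within the scatter, with a slight lean toward a lower number, giving a 1.5-fold lower number from compound 2 to compound 3 (0.17 log units; within the scatter) as the estimate. For compound 3 a value of 15000 nM is expected in this assay, within a range from 5000 nM to 45000 nM.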

Compound 3, half-maximal inhibitory concentration: 21900 nM
Compound 3: the middle estimate sits 1.5-fold (0.16 log units) below what was measured; the measured number falls inside the stated range.
By their numbers in this assay, from the lowest: compounds 1, 3 and 2 (each within the scatter of the next).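

In this assay, for the compounds shown here, the exchange of 4-methylphenyl for 4-(trifluoromethyl)phenyl gives a 1.0-fold lower number from compound 2 to compound 3 (0.01 log units; within the scatter), the first reading of any change at this place on the benzyl ether. Here, on an aromatic carbon para to a large group, 1 heavy atom gives way to 4 heavy atoms with no difference that can be told from the scatter, so this exchange does not separate the two compounds in this cell assay. Nothing available accounts for how closely the two values agree.

The compounds shown leave open whether a group of another kind at this place, such as an amine or a carboxylic acid, would move the number beyond the scatter. They also leave open whether the same exchange would read alike on the nitrile-bearing core of compound 1.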